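Purine Amino to Arylthio Swap and CaM Kinase II Inhibition

This account rests on a few compounds, and the source may have more. Where it says the series, first, only, none or still open, it means among the compounds named here.

Compound 1 `Clc1ncnc2ncn(Cc3ccccc3)c12`: 0%
Compound 2 `Nc1ncnc2c1ncn2Cc1ccc(F)cc1`: 9%

In an assay on isolated protein for inhibition of Ca2+/calmodulin-dependent protein kinase II (CaM kinase II) (Rattus norvegicus), tested at 30 uM (a higher number here means more inhibition at the concentration tested (going by the name of the read-out), a lower number less inhibition), compound 2 gives 9%, and compound 1 gives 0%; the two values lie within the usual scatter of each other, so neither compound can be set apart from the other on these numbers. Compound 3 `Fc1ccc(Cn2cnc3c(Sc4ccc(F)cc4)ncnc32)cc1` has not yet been measured. It differs from compound 2 in one place: (4-fluorophenyl)sulfanyl in place of amino on an aromatic carbon. For the measured compounds named here, no step between measured compounds is available to show what such a change does. The estimated step is a number 6 percentage points higher from compound 2 to compound 3 (within the scatter), expected to be small and uncertain in direction. Compound 3 is estimated to give 15%, within the range 0% to 45%.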

Compound 3, a percentage reported as inhibition, at one concentration (the size of the read-out at that concentration, not a potency): 0%
The estimate for compound 3 lay 15 percentage points above the measured number, within the range that was stated.
By their numbers in this assay, from the lowest: compounds 1, 3 and 2 (each within the scatter of the next).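

In this assay, (4-fluorophenyl)sulfanyl in place of amino on an aromatic carbon gives a number 9 percentage points lower from compound 2 to compound 3 (within the scatter). Exchanging a single-atom group for one of eight heavy atoms with its own aromatic ring therefore does not set compound 3 apart from compound 2 at the concentration tested. Nothing available explains this result.

The compounds shown leave open whether a methylsulfanyl group, a piperazine or a carboxylic acid on this aromatic carbon would give a number beyond the scatter of these values.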